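Swapping a Small Ethynyl for a Large Dimethoxyphenyl Group

The source may hold more compounds than are shown below. What is called first, only, known or untested is meant among the compounds shown, and "the series" means these compounds.

Three amides sharing one core have been tested in a functional assay on MDA-MB-231 cells (Homo sapiens) for antiproliferative activity, read by MTT assay, with a stated time of 72 h; a lower number here means a stronger inhibitor, a higher number a weaker inhibitor. Compound 1 (`CC(C)(C)NC(=O)CCc1cccc2c1B(O)OC2`) gives > 100000 nM, which is a limit of the assay and not a number. Compound 2 (`O=C(CCc1cccc2c1B(O)OC2)NCc1ccccc1`) gives > 100000 nM, again only a limit. Among the measured compounds shown here, compound 3 (`C#Cc1cccc(NC(=O)CCc2cccc3c2B(O)OC3)c1`) gives 1600 nM, the only true number among the three. The other two readings both sit at the limit of > 100000 nM in this assay, at which 2 of the 3 values shown sit.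

Compound 4 (`COc1cc(OC)cc(-c2cccc(NC(=O)CCc3cccc4c3B(O)OC4)c2)c1`) keeps the core and the amide of compound 3 and changes one group: 3,5-dimethoxyphenyl in place of ethynyl on an aromatic carbon.

For the measured compounds named here, the only measured step, a step that the two limits leave unreadable from compound 1 to compound 2, has no readable size, and it concerns an amide-type nitrogen, not the aromatic carbon changed here. It therefore gives no guide to the size or direction of this change. With no measured direction, the expectation stays near compound 3 at 1600 nM, with a wide margin on both sides. The expected change is a 1.3-fold higher number from compound 3 to compound 4 (0.10 log units; within the scatter), with no firm direction. The estimate for compound 4 is 2000 nM, with an expected range from 300 nM to 20000 nM.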

Compound 4, half-maximal inhibitory concentration: 40 nM
Beside the measured number, compound 4's estimate is 50-fold (1.70 log units) above it, and the stated range ends above it.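

Changing ethynyl to 3,5-dimethoxyphenyl on this aromatic carbon gives a 40-fold lower number from compound 3 to compound 4 (1.60 log units; beyond the scatter) in this assay. Among the compounds shown here, the one earlier step cannot be read and concerns the amide-type nitrogen, so this is the first sign that the aromatic carbon, at the far end of the amide, can strongly shift the number. This position also does not need a small group, at least in this pair: the 3,5-dimethoxyphenyl group that replaces ethynyl has more heavy atoms, with one six-membered aromatic ring and 2 hydrogen-bond acceptors, and the number still falls.

That single change swaps a triple bond for a ring and adds two methoxy groups all at once, so the compounds shown cannot separate the share of the ring from that of the methoxy groups, which a plain phenyl group or a phenyl group carrying one methoxy group would help to do. Nothing among the measurements shown explains why this change lowers the number.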